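The compounds below may be only part of what the source reports. "The series", "measured", "known", "first", "only" and "open" are said of these compounds alone.

Compound 1 `CCN(C1(C(=O)NO)CN(C(=O)C(C)C)C1)S(=O)(=O)c1ccc(OCc2cc(C)nc3ccccc23)cc1`: 11 uL/min
Compound 2 `COCCN(C1(C(=O)NO)CN(C(=O)C(C)C)C1)S(=O)(=O)c1ccc(OCc2cc(C)nc3ccccc23)cc1`: 18 uL/min

Of the compounds shown here, two have been measured in an ADME assay on cells (Hepatocyte, Homo sapiens) for metabolic stability, read by LC-MS, tested at 1 uM; on this read-out higher numbers stand for fast clearance and lower numbers for slow clearance. Compound 1 gives 11 uL/min, while compound 2 gives 18 uL/min. Compound 2 stands at the top of these two numbers, with compound 1 nearest, but the step of a 1.6-fold higher number from compound 1 to compound 2 (0.21 log units; within the scatter) is within the scatter, so the two cannot really be told apart.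

Compound 3 `Cc1cc(COc2ccc(S(=O)(=O)N(C(C)C)C3(C(=O)NO)CN(C(=O)C(C)C)C3)cc2)c2ccccc2n1` has not been measured yet. It differs from compound 2 by isopropyl in place of 2-methoxyethyl on a sulfonamide nitrogen. Within the data shown here, only one measured step bears on this change, since a 1.6-fold higher number from compound 1 to compound 2 (0.21 log units; within the scatter) also swapped the group on the same sulfonamide nitrogen, and it stayed within the scatter. Nothing seen so far suggests that the group on this nitrogen moves the number beyond the scatter, so for compound 3 a step of about a 1.4-fold lower number from compound 2 to compound 3 (0.14 log units; within the scatter) is expected in this assay, that is, no change beyond the scatter. Compound 3 is therefore estimated at 13 uL/min, with a range from 6 uL/min to 28 uL/min.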

Compound 3, intrinsic clearance in a liver preparation (reported as CLH), per the amount of preparation that the assay uses in the Hepatocyte assay: 17 uL/min
Compound 3: middle estimate off by 1.3-fold (0.12 log units), on the low side, and the stated range covers the measured number.
By their numbers in the Hepatocyte assay, from the lowest: compounds 1, 3 and 2 (each within the scatter of the next).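

In the Hepatocyte assay, putting isopropyl in place of 2-methoxyethyl on the sulfonamide nitrogen gives a 1.1-fold lower number from compound 2 to compound 3 (0.02 log units; within the scatter), and the other new step, a 1.5-fold higher number from compound 1 to compound 3 (0.19 log units; within the scatter), also stays within the scatter, so the three groups seen at this position cannot be told apart by clearance. A second read-out separates two of them: in a physicochemical assay for solubility, with a stated time of 24 h, tested at 30 mg/mL (a higher number here means a more soluble compound, a lower number a less soluble compound), compound 2 gives 8900000 nM and compound 3 gives 2200000 nM. This is the first time a change on this nitrogen moves a number beyond the scatter, so a swap that leaves clearance unchanged within the scatter still comes with a real loss in the physicochemical assay: the measured solubility of compound 2, 8900000 nM, and of compound 3, 2200000 nM, a 4.0-fold lower number (0.61 log units; beyond the scatter)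

Among these compounds, only this one pair can be compared for solubility, so it stays open whether the drop follows the loss of the oxygen in 2-methoxyethyl or the branched shape of isopropyl. From the compounds shown here alone, it also stays open whether an amine or a carboxylic acid on the chain, or a longer chain, would keep clearance within the same scatter while changing solubility.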